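The source may report more compounds than this note shows. Statements on the series, on what has been measured and on what is new or still open speak of the compounds shown alone.

Values measured so far in a functional assay on MOLT-4 cells (Homo sapiens) for antiproliferative activity, read by MTT assay, with a stated time of 48 h; on this read-out lower numbers stand for stronger inhibition and higher numbers for weaker inhibition:

- compound 1 `O=C(CCCCCCn1cc(Nc2ncc(Cl)c(Nc3ccc(F)cc3)n2)cn1)NO` gives 220 nM
- compound 2 `O=C(CCCCCn1cc(Nc2ncc(Cl)c(Nc3ccc(F)cc3)n2)cn1)NO` gives 120 nM
- compound 3 `O=C(CCCCCn1cc(Nc2ncc(Cl)c(Nc3ccc(Cl)cc3)n2)cn1)NO` gives 80 nM

Compound 1 stands at the upper end of these numbers. Its nearest neighbour lies one small step away (a 1.8-fold lower number from compound 1 to compound 2 (0.26 log units; within the scatter)), while compound 3 lies beyond the scatter from it.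

The next compound is compound 4 `O=C(CCCCCCn1cc(Nc2ncc(Cl)c(Nc3ccccc3Cl)n2)cn1)NO`, which keeps the chain of compound 1. The change is 2-chlorophenyl in place of 4-fluorophenyl on a nitrogen on an aromatic ring.

Among the compounds with values here, the only measured step that bears on this is the exchange of fluoro for chloro (a 1.5-fold lower number from compound 2 to compound 3 (0.18 log units; within the scatter)), seen on the chain of compound 2. The chain step does not apply here. Within the data shown here, no measured compound carries a 2-chlorophenyl, so that part of the change is untested. In this assay a small lean towards a lower number is expected, but no step beyond the scatter. The estimated step is small (a 1.3-fold lower number from compound 1 to compound 4 (0.11 log units; within the scatter)). Compound 4 is expected at 170 nM within an estimated range of 70 nM to 420 nM in this read-out.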

Compound 4, half-maximal inhibitory concentration: 510 nM
Compound 4: middle estimate off by 3.0-fold (0.48 log units), on the low side; the measured number lies above the stated range.
By their numbers in this assay, from the lowest: compounds 3, 2 and 1 (each within the scatter of the next, the first and the last beyond it); then compound 4.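

In this assay, within the data shown here, replacing 4-fluorophenyl with 2-chlorophenyl on the nitrogen gives a 2.3-fold higher number from compound 1 to compound 4 (0.37 log units; beyond the scatter), the first single-place change to go beyond the scatter. This shows that the aryl group on this nitrogen can move the read-out, whereas the earlier exchange of fluoro for chloro, on the chain of compound 2, gave only a 1.5-fold lower number from compound 2 to compound 3 (0.18 log units; within the scatter). No measurement shown accounts for the higher number.

The step changes both the halogen and its ring position, so the compounds shown cannot separate the two contributions. As far as these compounds go, it remains open how an unsubstituted phenyl or a 2-fluorophenyl would read on this nitrogen, and whether 2-chlorophenyl gives a similar step on the chain of compound 2.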